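Swapping a Sulfonyl Cap for a Formyl Cap

The source may report more compounds than this note shows. Statements on the series, on what has been measured and on what is new or still open speak of the compounds shown alone.

Of the compounds shown here, two sharing one core have been tested in an ADME assay on TZM cells (Homo sapiens) for cytotoxicity, with a stated time of 1 days; a higher number here means that more compound is tolerated, a lower number that less compound is tolerated. Compound 1 `C#CCNC(=O)/C=C/c1cnc(Nc2ccc(C#N)cc2)nc1Oc1c(C)cc(C#N)cc1C` gives > 222 nM, which is a limit of the assay rather than a number. Compound 2 `Cc1cc(C#N)cc(C)c1Oc1nc(Nc2ccc(C#N)cc2)ncc1/C=C/C(=O)N1CCN(S(=O)(=O)C(F)(F)F)CC1` gives > 164 nM, again a limit and not a number. Among the measured compounds shown here, compound 2 thus stands at the limit of > 164 nM in this assay, at which 1 of the 2 values shown sits, while the only other value shown sits at the limit of > 222 nM in this assay, at which 1 of the 2 values shown sits, so both measured compounds are known only as limits. Compound 3 `Cc1cc(C#N)cc(C)c1Oc1nc(Nc2ccc(C#N)cc2)ncc1/C=C/C(=O)N1CCN(C=O)CC1` is the next candidate, and it differs from compound 2 by formyl in place of (trifluoromethyl)sulfonyl on an amine nitrogen in a ring. For the measured compounds named here, since no step between measured compounds exists, the expected change in this assay is none beyond the usual scatter, with compound 3 most likely reaching a limit once more. The estimated step is a step that the limit leaves unreadable from compound 2 to compound 3. Compound 3 is therefore expected to show about 200 nM, with a range from 100 nM to 500 nM.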

Compound 3, half-maximal cytotoxic concentration: > 197 nM
Compound 3: a limit, no number; the forecaster's own chance of this, stated with the estimate: 75%; the middle value is on the limit's open side.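

Compound 3 gives > 197 nM, which is a limit of the assay and not a number. Compound 1 and compound 2 are also known only as limits, so neither step to compound 3 can be read. The compounds shown leave open whether formyl in place of (trifluoromethyl)sulfonyl changes the result in this assay at all.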